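From Phenyl to a Methoxymethoxy Aryl Group in Compound 4

The source may hold more compounds than are shown below. What is called first, only, known or untested is meant among the compounds shown, and "the series" means these compounds.

In an ADME assay on PA-1 cells (Homo sapiens) for cytotoxicity, read by MTT assay, with a stated time of 72 h (on this read-out lower numbers stand for stronger inhibition and higher numbers for weaker inhibition), compound 1 `COc1ccc(OC)c(C2=C(c3cc(OC)c(OC)c(OC)c3)C(=O)CC2O[SiH2]C(C)(C)C)c1` gives 17 ug/mL. Compound 2 `COC(=O)c1cc(C2=C(c3cc(OC)c(OC)c(OC)c3)C(=O)CC2O[SiH2]C(C)(C)C)ccc1OC` reads > 100 ug/mL, which is a limit of the assay and not a number. Compound 3 `COc1cc(C2=C(c3ccccc3)C(O[SiH2]C(C)(C)C)CC2=O)cc(OC)c1OC` reads > 100 ug/mL, also a limit. That places compound 3 at the limit of > 100 ug/mL in this assay, at which 2 of the 3 values shown sit, with no number of its own.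

Compound 4 `COCOc1cc(C2=C(c3cc(OC)c(OC)c(OC)c3)C(=O)CC2O[SiH2]C(C)(C)C)ccc1OC` carries 4-methoxy-3-(methoxymethoxy)phenyl in place of phenyl on a double-bonded ring carbon. Going by the values given here, two measured steps bear on this change. The step of an at least 5.8-fold higher number from compound 1 to compound 3 (0.76 log units; beyond the scatter) reaches the limit when phenyl replaces 2,5-dimethoxyphenyl, so a substituted aryl group can matter here. The step of an at least 5.8-fold higher number from compound 1 to compound 2 (0.76 log units; beyond the scatter) goes against any simple reading, since the substituted aryl group of compound 2 also reaches the limit. Both steps are bounded rather than exact.

The expected change is an at least 2.5-fold lower number from compound 3 to compound 4 (0.39 log units; beyond the scatter), an estimated move toward stronger inhibition of modest size, with a real chance of no number at all. For compound 4 the estimate is 40 ug/mL, with an expected range of 10 ug/mL to 150 ug/mL.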

Compound 4, half-maximal inhibitory concentration: 13.5 ug/mL
Beside the measured number, compound 4's estimate is 3.0-fold (0.47 log units) above it, and the stated range covers the measured number.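

In this assay, the aryl group on the double-bonded ring carbon decides whether a number is reached at all: 4-methoxy-3-(methoxymethoxy)phenyl in place of phenyl gives an at least 7.4-fold lower number from compound 3 to compound 4 (0.86 log units; beyond the scatter), and methoxymethoxy in place of methoxycarbonyl on an aromatic carbon gives an at least 7.4-fold lower number from compound 2 to compound 4 (0.86 log units; beyond the scatter). Going by these compounds alone, the 2,5-dimethoxyphenyl group is thus not the only aryl group here that gives a measurable value, as the comparison with it gives a 1.3-fold lower number from compound 1 to compound 4 (0.10 log units; within the scatter). The first two steps start from a limit and not a number, so their true size stays unknown: the limit of > 100 ug/mL in this assay, at which 2 of the 4 values shown sit.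

The compounds shown leave open whether a hydroxyl group, an amine or a longer alkoxy chain in place of methoxymethoxy would keep this level. They also leave open whether methoxymethoxy itself matters or whether a plain methoxy group would serve as well.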